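Chloro for methoxy on a selenocyanate phenylcarbamate

This account rests on a few compounds, and the source may have more. Where it says the series, first, only, none or still open, it means among the compounds named here.

Measured so far in a functional assay on HT-29 cells (Homo sapiens) for cytotoxicity, read by MTT assay, with a stated time of 72 h; on this read-out lower numbers stand for higher toxicity in this test and higher numbers for lower toxicity in this test:
Compound 1, `COc1ccc(OC(=O)Nc2ccc([Se]C#N)cc2)cc1`, gives 69600 nM.
Compound 2, `CCCCOC(=O)Nc1ccc([Se][Se]c2ccc(NC(=O)OCCCC)cc2)cc1`, gives 82400 nM.

Of these two numbers, compound 1 carries the lower one, but compound 2 sits within the usual scatter of it, so the two cannot be told apart in this assay. Compound 3, `N#C[Se]c1ccc(NC(=O)Oc2ccc(Cl)cc2)cc1`, has not yet been measured there. It differs from compound 1 in a single place: chloro in place of methoxy on an aromatic carbon. Among the measured compounds shown here, no measured pair shows what this particular exchange does, so there is nothing to copy from. Both measured compounds lie in one narrow band, which gives no reason to expect a large move in either direction. The expected step is a 1.2-fold lower number from compound 1 to compound 3 (0.06 log units; within the scatter), no larger than the scatter. Compound 3 is therefore estimated at 60000 nM, within a range from 25000 nM to 150000 nM.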

Compound 3, concentration lethal to 50% of the cells: 68700 nM
The estimate for compound 3 lay 1.1-fold (0.06 log units) below the measured number; the range from low to high includes it.
By their numbers in this assay, from the lowest: compounds 3, 1 and 2 (each within the scatter of the next).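

Chloro in place of methoxy on an aromatic carbon, para to a large group, brings a 1.0-fold lower number from compound 1 to compound 3 (0.01 log units; within the scatter) in this assay and so makes no difference that this test can detect. Among the compounds shown here, this is the first direct look at this position, and it shows that the methoxy group, with its oxygen, can give way to a lone chlorine atom while the number stays within the scatter. No further data bear on this result.

Going by these compounds, whether an amine, a carboxylic acid or a longer chain at this same carbon would shift the number beyond the scatter stays open. Compound 2 differs from compound 1 and compound 3 in more than one place, so it adds nothing about this position.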